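Working notes: from compound 3 to compound 4

The compounds below may be only part of what the source reports. "The series", "measured", "known", "first", "only" and "open" are said of these compounds alone.

- compound 1 `CCCc1ccc(-c2cc(=O)c3c(o2)C(CC)(CC)C(=O)C(CC)=C3O)cc1` gives 12.2 uM
- compound 2 `CCC1=C(O)c2c(oc(-c3ccc(Br)cc3)cc2=O)C(CC)(CC)C1=O` gives 15.7 uM
- compound 3 `CCC1=C(O)c2c(oc(-c3ccc(COC)cc3)cc2=O)C(CC)(CC)C1=O` gives 3.4 uM

In a functional assay on KBVIN cells (Homo sapiens) for antiproliferative activity, read by sulforhodamine B assay, with a stated time of 3 days (on this read-out lower numbers stand for an effect already at smaller amounts and higher numbers for an effect only at larger amounts of compound), compound 3 has the lowest of the three numbers, with a 3.6-fold lower number from compound 1 to compound 3 (0.55 log units; beyond the scatter) and a 4.6-fold lower number from compound 2 to compound 3 (0.66 log units; beyond the scatter), both beyond the scatter. Compound 4 `CCC1=C(O)c2c(oc(-c3cccc(OC)c3)cc2=O)C(CC)(CC)C1=O` is unmeasured. Its change is 3-methoxyphenyl in place of 4-(methoxymethyl)phenyl on an aromatic carbon. Among the compounds with values here, no measured compound carries the entering group, so the evidence is indirect. Compound 1 and compound 2 lie within the scatter of each other, with a 1.3-fold higher number from compound 1 to compound 2 (0.11 log units; within the scatter), and both sit modestly higher than compound 3. A modest rise in this assay is therefore expected. The expected step is a 2.1-fold higher number from compound 3 to compound 4 (0.31 log units; beyond the scatter). The estimate for compound 4 is 7 uM, with an expected range from 2.5 uM to 20 uM.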

Compound 4, concentration for half-maximal effect: 1.22 uM
Compound 4: the middle estimate sits 5.7-fold (0.76 log units) above what was measured; the measured number lies below the stated range.
By their numbers in this assay, from the lowest: compound 4; then compound 3; then compounds 1 and 2 (each within the scatter of the next).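

In this assay the 3-methoxyphenyl group of compound 4 gives the lowest number of the set, with a 2.8-fold lower number from compound 3 to compound 4 (0.45 log units; beyond the scatter), a 10-fold lower number from compound 1 to compound 4 (1.00 log units; beyond the scatter) and a 13-fold lower number from compound 2 to compound 4 (1.11 log units; beyond the scatter). This position therefore accepts a group that gains beyond what 4-propylphenyl, 4-bromophenyl and 4-(methoxymethyl)phenyl showed, although the swap changes both the substituent and where it sits on the phenyl ring. Nothing in the available data accounts for this gain.

The effects of substituent identity and placement remain unseparated. Also open, as far as these compounds go, is whether an amine or a hydroxyl in place of the methoxy of 3-methoxyphenyl would keep the number this low.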